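A few compounds are considered here, and "the series" means these few. Any claim that something is new, unique, unknown or untested is made for them only; others in the source may bear on it.

In a physicochemical assay for lipophilicity (a lower number here means a more polar compound, a higher number a more lipophilic compound), compound 2 `CC(C)Sc1nnc(-c2c(CNc3nc4ccccc4[nH]3)c3ccccc3n2C)n1-c1ccccc1` gives 5.94, the lowest of the three numbers measured here; compound 1 `COc1ccc(CNCc2c(-c3nnc(SC(C)C)n3-c3ccccc3)n(C)c3ccc(F)cc23)cc1` gives 6.42 and compound 3 `COc1cccc(CNCc2c(-c3nnc(SC(C)C)n3-c3ccccc3)n(C)c3ccc(F)cc23)c1` gives 6.42, both higher by steps beyond the scatter. Within the data shown here, the one step measured between single changes, no change at the digits printed from compound 1 to compound 3 (within the scatter), concerns a methoxyphenyl group and does not touch the part that changes here. Compound 4 `CC1CN(Cc2c(-c3nnc(SC(C)C)n3-c3ccccc3)n(C)c3ccccc23)CC(C)O1` differs from compound 2 by 2,6-dimethylmorpholin-4-yl in place of (1H-benzimidazol-2-yl)amino on a saturated chain carbon bound to an aromatic carbon. Among the measured compounds shown here, no measured step bears on this exchange, so the direction rests on the change itself: the leaving group carries two aromatic rings and two donors, the entering group none of either. A downward step in this assay is therefore expected, a number 0.54 log units lower from compound 2 to compound 4 (beyond the scatter), with wide uncertainty. Compound 4 is estimated at 5.4, from 4.7 to 6.1.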

Compound 4, partition coefficient: 5.13
For compound 4 the middle estimate is 0.27 log units above the measured one; measured number inside the range.
By their numbers in this assay, from the lowest: compound 4; then compound 2; then compounds 1 and 3 (each within the scatter of the next).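

In this assay, putting 2,6-dimethylmorpholin-4-yl in place of (1H-benzimidazol-2-yl)amino on a saturated chain carbon bound to an aromatic carbon gives a number 0.81 log units lower from compound 2 to compound 4 (beyond the scatter) and so shows that the group held at this place can move the number beyond the scatter. The earlier single-change step concerned only a methoxyphenyl group elsewhere and left this place untested. Nothing available here explains the size of this step. 

Still open, going by these compounds, is how much of the step belongs to the leaving group and how much to the entering one. A piperidin-1-yl or dimethylamino group at the same place could help separate the two.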